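The source may hold more compounds than are shown below. What is called first, only, known or untested is meant among the compounds shown, and "the series" means these compounds.

Compound 1 `O=S(=O)(CC1=NCCS1)c1c(-c2ccc(Cl)cc2)noc1-c1ccc(Cl)cc1` and compound 3 `O=S(=O)(CC1=NCCO1)c1c(-c2ccc(Cl)cc2)noc1-c1ccc(Cl)cc1` share a core; compound 2 `COc1ccc(-c2nn(-c3ccccc3)c(-c3ccc(C)cc3)c2S(=O)(=O)CC2=NCCO2)cc1` has a different core. In a functional assay, read by Griess assay, with a stated time of 150 min, tested at 75 ug/mL (on this read-out lower numbers stand for a weaker effect and higher numbers for a stronger effect at the one concentration tested), compound 1 is recorded as "not active" (no number reported), with no number. In this assay compound 2 gives 66.6%. Compound 3 differs from compound 1 in one group (a group of 5 heavy atoms (3 carbon, 1 nitrogen, 1 oxygen; one five-membered non-aromatic ring with 2 hetero atoms) in place of a group of 5 heavy atoms (3 carbon, 1 nitrogen, 1 sulfur; one five-membered non-aromatic ring with 2 hetero atoms), on a saturated chain carbon bound to a sulfonyl sulfur). Only compound 1 carries this core, and it was reported inactive, so no step beyond the scatter is expected from this change. Compound 3 is therefore expected to give about 15%, estimated between 0% and 45%, though it may again be reported without a number.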

Compound 3, a percentage reported as activity, at one concentration (the size of the read-out at that concentration, not a potency): "not active" (no number reported)
Compound 3: no number reported; no gap can be computed for the estimate.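

In this assay neither compound 1 nor compound 3 has a number, so no step can be read between them. No evidence bears on this result. From the compounds shown here alone, whether swapping sulfur for oxygen in the five-membered ring changes the effect on this core stays open.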